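The compounds below may be only part of what the source reports. "The series", "measured", "known", "first", "only" and "open" are said of these compounds alone.

Measured so far in an assay on isolated protein for inhibition of ubiquitin carboxyl-terminal hydrolase 7 (Homo sapiens), with stated times of 30 min and 2 h; a higher number here means a weaker inhibitor, a lower number a stronger inhibitor:

- compound 1 `Cn1nc2c(=O)n(CC3(O)CCN(Cc4ccc(-c5cnco5)cc4Cl)CC3)cnc2c1-c1ccc(CN)cc1`: 71.6 nM
- compound 2 `Cn1nc2c(=O)n(CC3(O)CCN(Cc4ccc(-c5ccco5)cc4Cl)CC3)cnc2c1-c1ccc(CNCCO)cc1`: 8.2 nM
- compound 3 `Cn1nc2c(=O)n(CC3(O)CCN(Cc4ccc(-c5ncco5)cc4Cl)CC3)cnc2c1-c1ccc(CN)cc1`: 1120 nM

Compound 2 gives the lowest number of the three; compound 1 stands nearest to it and compound 3 furthest, both gaps beyond the scatter. Compound 2 differs from compound 1 in more than one place, so the two values alone say nothing about any single change. Going by the values given here, the only single-point step measured, a 16-fold higher number from compound 1 to compound 3 (1.19 log units; beyond the scatter), concerns the exchange of 1,3-oxazol-5-yl for 1,3-oxazol-2-yl on the benzylic ring and says nothing about the chain on the amine.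

Compound 4 `CCCNCc1ccc(-c2c3ncn(CC4(O)CCN(Cc5ccc(-c6ccco6)cc5Cl)CC4)c(=O)c3nn2C)cc1` is the next entry and differs from compound 2 by methyl in place of hydroxy on a saturated chain carbon, two bonds along the chain from an amine nitrogen, that is, 2-hydroxyethyl becomes propyl on the amine. Among the compounds with values here, no measured step bears on this change, so there is no basis for expecting a shift beyond the scatter in either direction. The step expected is a 1.5-fold higher number from compound 2 to compound 4 (0.17 log units; within the scatter). Compound 4 is therefore estimated at 12 nM, in the range 4 nM to 35 nM.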

Compound 4, half-maximal inhibitory concentration: 43.9 nM
The estimate for compound 4 lay 3.7-fold (0.56 log units) below the measured number; the whole stated range lies below it.
By their numbers in this assay, from the lowest: compound 2; then compounds 4 and 1 (each within the scatter of the next); then compound 3.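

In this assay, the side chain on the amine now has a measured effect: replacing 2-hydroxyethyl with propyl gives a 5.4-fold higher number from compound 2 to compound 4 (0.73 log units; beyond the scatter), so this position is sensitive to the exchange of hydroxy for methyl. Going by these compounds alone, this is the first single-point step read at this chain, whereas the earlier one concerned only the oxazolyl attachment on the benzylic ring. No data at hand explain the step.

One pair cannot show whether the hydroxy group itself matters or whether other chains would serve as well; a 2-methoxyethyl group, a 2-aminoethyl group, a carboxylic acid or a longer hydroxyalkyl chain at this amine would test that. On these data alone, whether the step carries over to compounds bearing 1,3-oxazol-5-yl also remains open.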